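The source may report more compounds than this note shows. Statements on the series, on what has been measured and on what is new or still open speak of the compounds shown alone.

Measured so far:
compound 1, `Cc1nc(C(F)(F)F)ccc1CNC(=O)C(C)c1ccc(NS(C)(=O)=O)c(F)c1`, 387 nM
compound 2, `CCCCCc1nc(C(F)(F)F)ccc1CNC(=O)C(C)c1ccc(NS(C)(=O)=O)c(F)c1`, 1 nM
compound 3, `CC(C(=O)NCc1ccc(C(F)(F)F)nc1C1=CCC(C)(C)CC1)c1ccc(NS(C)(=O)=O)c(F)c1`, 0.2 nM

In an assay on CHO cells for antagonist activity at transient receptor potential cation channel subfamily V member 1 (Homo sapiens), read by FLIPR and calcium flux (on this read-out higher numbers stand for weaker inhibition and lower numbers for stronger inhibition), compound 2 gives 1 nM, the second highest of the three numbers. Its nearest neighbour is reached by a 5.0-fold lower number from compound 2 to compound 3 (0.70 log units; beyond the scatter), its furthest by a 390-fold lower number from compound 1 to compound 2 (2.59 log units; beyond the scatter).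

Compound 4, `CCC/C=C/c1nc(C(F)(F)F)ccc1CNC(=O)C(C)c1ccc(NS(C)(=O)=O)c(F)c1`, differs from compound 2 in one place: pent-1-en-1-yl in place of pentyl on an aromatic carbon. Among the compounds with values here, two measured steps bear on this aromatic carbon. a 390-fold lower number from compound 1 to compound 2 (2.59 log units; beyond the scatter) shows that the chain grown there moved the number a long way; a 5.0-fold lower number from compound 2 to compound 3 (0.70 log units; beyond the scatter) shows that trading the pentyl for a ring holding a double bond lowered the number modestly. The change to pent-1-en-1-yl keeps the same count of carbons and adds one double bond outside aromatic rings, a smaller alteration than either of those. The account therefore expects only a small shift, if any, most likely downward and within the scatter: a 1.4-fold lower number from compound 2 to compound 4 (0.15 log units; within the scatter). Compound 4 is estimated at 0.7 nM, within 0.2 nM to 2.5 nM.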

Compound 4, inhibition constant: 0.9 nM
For compound 4 the middle estimate is 1.3-fold (0.11 log units) below the measured one, and the stated range covers the measured number.
By their numbers in this assay, from the lowest: compound 3; then compounds 4 and 2 (each within the scatter of the next); then compound 1.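

In this assay, pent-1-en-1-yl in place of pentyl on this aromatic carbon, next to the ring nitrogen, leaves the number within the scatter (a 1.1-fold lower number from compound 2 to compound 4 (0.05 log units; within the scatter)), so the added double bond in the open chain makes no measurable difference here. The large difference from methyl holds with the unsaturated chain as well (a 430-fold lower number from compound 1 to compound 4 (2.63 log units; beyond the scatter)), while the step to the open chain from 4,4-dimethylcyclohex-1-en-1-yl is modest but beyond the scatter (a 4.5-fold higher number from compound 3 to compound 4 (0.65 log units; beyond the scatter)), so a double bond alone does not match what that ring gives. No measurement at hand offers a reason for either result.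

The compounds shown leave open whether the ring itself or its two methyl groups matter more, since a plain cyclohexenyl group does not appear among them. They also leave open how a longer chain, or an amine, would read at this carbon.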